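Three aryl ureas measured, an acetyl analogue estimated

The source may hold more compounds than are shown below. What is called first, only, known or untested is meant among the compounds shown, and "the series" means these compounds.

Measured so far:
compound 1, `N#CC1CN1C(=O)Nc1ccc(F)cc1`, 5900 nM
compound 2, `N#CC1CN1C(=O)Nc1ccc([N+](=O)[O-])cc1`, 2600 nM
compound 3, `N#CC1CN1C(=O)Nc1ccccc1`, 11000 nM

All three were read in a functional assay on L1210 cells (Mus musculus) for inhibition, read by MTT assay; a lower number here means a stronger inhibitor, a higher number a weaker inhibitor. Compound 3 carries the highest of the three numbers, though not all of its distances are meaningful: a 1.9-fold higher number from compound 1 to compound 3 (0.27 log units; within the scatter), whereas a 4.2-fold higher number from compound 2 to compound 3 (0.63 log units; beyond the scatter). Among the compounds with values here, the substituted members so far, compound 1 and compound 2, therefore sit at or below compound 3 in this assay, with a modest shift for the nitro case and no clear shift for the fluoro case.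

Compound 4, `CC(=O)c1cccc(NC(=O)N2CC2C#N)c1`, differs from compound 3 by one change: acetyl in place of hydrogen on an aromatic carbon. Within the data shown here, neither measured step probes this place on the ring, so the precedent is indirect; it says only that placing a group on the bare ring of compound 3 has so far either left the number unchanged or lowered it modestly. A similar modest step downward, or none beyond the scatter, is expected here: a 2.2-fold lower number from compound 3 to compound 4 (0.34 log units; beyond the scatter). The estimate for compound 4 is 5000 nM, with a range from 2000 nM to 13000 nM.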

Compound 4, half-maximal inhibitory concentration: 7900 nM
Compound 4: middle estimate off by 1.6-fold (0.20 log units), on the low side; low and high end bracket the measured number.
By their numbers in this assay, from the lowest: compound 2; then compounds 1, 4 and 3 (each within the scatter of the next).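

Compound 4 gives a reading at a place on the ring that the other compounds do not probe: in this assay, acetyl in place of hydrogen, meta to a group of 8 heavy atoms, gives a 1.4-fold lower number from compound 3 to compound 4 (0.14 log units; within the scatter), with no shift that can be told from the scatter. Acetyl, with its 3 heavy atoms, is thus accepted at this place, and it joins fluoro as a change without a clear shift, while nitro remains the only group with a step beyond the scatter. Nothing available here bears on the reason for this result.

Going by these compounds, whether an amine or a carboxylic acid at this place would move the number beyond the scatter stays open. Also open, on these data alone, is whether nitro keeps its step at this place, and how acetyl reads at the place held by fluoro in compound 1 and nitro in compound 2.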